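Carbamate in Place of Carboxamide: Estimating Compound 4

The source may report more compounds than this note shows. Statements on the series, on what has been measured and on what is new or still open speak of the compounds shown alone.

Measured in an assay on CHO-K1 cells for displacement of a labelled ligand from prostaglandin E2 receptor EP1 subtype (Homo sapiens); a lower number here means a stronger inhibitor, a higher number a weaker inhibitor:
compound 1, `Cc1cc(C(=O)O)nn1C(C)c1cc(Cl)ccc1OCc1ccccc1`, gives 10 nM;
compound 2, `Cc1cc(C(=O)NCc2ccccn2)nn1Cc1cc(Cl)ccc1OCc1ccccc1`, gives 25.1 nM;
compound 3, `Cc1cc(C(=O)NN2CCOCC2)nn1Cc1cc(Cl)ccc1OCC(C)C`, gives 251 nM.

Compound 2 stands second highest of the three numbers. Its nearest neighbour is compound 1, whose number is lower, beyond the usual scatter; the furthest is compound 3, whose number is higher, again beyond the scatter. Going by the values given here, no two of the measured compounds differ in only one place, so no single step between them is known.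

Compound 4, `Cc1cc(NC(=O)OCc2ccccc2)nn1Cc1cc(Cl)ccc1OCc1ccccc1`, has not yet been measured. It differs from compound 2 in one place: (benzyloxycarbonyl)amino in place of ((pyridin-2-yl)methyl)carbamoyl on an aromatic carbon. The change sits on an aromatic carbon of a five-membered aromatic ring with 2 nitrogen, next to the ring nitrogen. Among the compounds with values here, with no measured step to lean on, the direction is uncertain; a moderately higher number is expected in this assay, that is, a step of a 2.4-fold higher number from compound 2 to compound 4 (0.38 log units; beyond the scatter) beyond the scatter but not large. Compound 4 is estimated at 60 nM, with a range from 15 nM to 250 nM.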

Compound 4, half-maximal inhibitory concentration: 79.4 nM
Compound 4: the middle estimate sits 1.3-fold (0.12 log units) below what was measured, and the stated range covers the measured number.
By their numbers in this assay, from the lowest: compound 1; then compound 2; then compound 4; then compound 3.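

In this assay, going by these compounds alone, the change of ((pyridin-2-yl)methyl)carbamoyl to (benzyloxycarbonyl)amino gives the first single-place comparison at this aromatic carbon, and the step is a 3.2-fold higher number from compound 2 to compound 4 (0.50 log units; beyond the scatter), a modest loss of potency rather than a collapse. The position therefore accepts a group in which nitrogen, not the carbonyl, is attached to the ring, and in which a six-membered aromatic ring of carbon only replaces the one with a hetero atom, although both differences arrive together and this step cannot separate them. Nothing available explains the step.

It remains open which of the two differences accounts for the step. Going by these compounds, a benzyl carboxamide or a benzyl urea at this carbon would bear on that question, and whether either would lie closer to compound 2 or to compound 4 is unknown.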